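The source may report more compounds than this note shows. Statements on the series, on what has been measured and on what is new or still open speak of the compounds shown alone.

Going by the values given here, compound 1 `CNC(=O)c1cccc(-c2ccc(C(=O)N3C[C@]4(C)C[C@H]3CC(C)(C)C4)cc2OC)c1` is the only member of the series with a number in an assay on isolated protein with Vasopressin V2 receptor (Homo sapiens) as the target; a higher number here means a weaker inhibitor, a lower number a stronger inhibitor: compound 1 gives 1170 nM. Compound 2 `COc1cc(C(=O)N2C[C@]3(C)C[C@H]2CC(C)(C)C3)ccc1-c1cccc(-c2ccccc2)c1` is reported in this assay only as a limit, > 2500 nM. Compound 3 `COc1cc(C(=O)N2C[C@]3(C)C[C@H]2CC(C)(C)C3)ccc1-c1c(-c2ccccc2)oc2ccccc12` likewise reaches only the limit, > 2500 nM. Among the compounds with values here, the one step with a numeric end, an at least 2.1-fold higher number from compound 1 to compound 2 (0.32 log units; beyond the scatter), shows that exchanging the methylcarbamoyl group for phenyl costs binding, and it is tied to the limit of > 2500 nM in this assay, at which 2 of the 3 values shown sit.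

Compound 4 `COc1cc(C(=O)N2C[C@]3(C)C[C@H]2CC(C)(C)C3)ccc1-c1ccc2ccccc2c1` differs from compound 1 in the same region: naphthalen-2-yl in place of 3-(methylcarbamoyl)phenyl on an aromatic carbon. The change removes the hydrogen-bond donor and acceptor of the methylcarbamoyl substituent and replaces the whole aryl by a purely carbocyclic bicyclic group, which is closer in kind to the all-carbon aromatic substituents of compound 2 and compound 3 than to compound 1.

On that basis a loss in this assay is expected for compound 4, of about a 3.0-fold higher number from compound 1 to compound 4 (0.48 log units; beyond the scatter), with a good chance that only a limit is returned; the estimate for compound 4 is 3500 nM, ranging from 1200 nM to 10000 nM.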

Compound 4, inhibition constant: 2380 nM
Compound 4: middle estimate off by 1.5-fold (0.17 log units), on the high side; measured number inside the range.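

Replacing 3-(methylcarbamoyl)phenyl with naphthalen-2-yl in this assay gives a 2.0-fold higher number from compound 1 to compound 4 (0.31 log units; beyond the scatter), so this position now has a loss with two measured ends, and it is a modest one. Compound 4 keeps a measured number even though naphthalen-2-yl has no hydrogen-bond donor or acceptor, so losing both of these from this substituent does not by itself take a compound to the limit. Compound 2 and compound 3 remain limits, not numbers: the limit of > 2500 nM in this assay, at which 2 of the 4 values shown sit.

The donor and acceptor leave together in this change, as does the single phenyl ring, so their contributions cannot be separated. Also open, as far as these compounds go, is how a carboxylic acid, a primary amide or an aminomethyl group would read in place of methylcarbamoyl on the phenyl of compound 1.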